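The source may report more compounds than this note shows. Statements on the series, on what has been measured and on what is new or still open speak of the compounds shown alone.

Measured compounds:
compound 1 `CC(C)(C)Cc1cnc(CCc2ccc(-c3ccccc3C(=O)O)cc2)[nH]1` with 6.3 nM
compound 2 `O=C(O)c1ccccc1-c1ccc(CCc2ncc(Cc3cccc(F)c3F)[nH]2)cc1` with 8 nM

Compound 2 sits next to compound 1 in an in vitro functional assay on cells for agonist activity at Bombesin receptor subtype-3 (Mus musculus), read by luminescence and calcium flux; on this read-out higher numbers stand for an effect only at larger amounts of compound and lower numbers for an effect already at smaller amounts; the step of a 1.3-fold higher number from compound 1 to compound 2 (0.10 log units; within the scatter) puts the two within the scatter of each other, so neither stands apart. Compound 3 `O=C(O)c1ccccc1-c1ccc(CCc2ncc(Cc3ccccc3)[nH]2)cc1` differs from compound 2 by phenyl in place of 2,3-difluorophenyl on a saturated chain carbon bound to an aromatic carbon. Within the data shown here, the only related step is the one from compound 1 to compound 2, in which a swap at the same saturated chain carbon left this assay essentially unchanged. The expected step is therefore none beyond the scatter, no change at the digits printed from compound 2 to compound 3 (within the scatter). For compound 3 the estimate is 8 nM, with a range from 3 nM to 20 nM.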

Compound 3, half-maximal effective concentration: 11 nM
Beside the measured number, compound 3's estimate is 1.4-fold (0.14 log units) below it, within the range that was stated.
By their numbers in this assay, from the lowest: compounds 1, 2 and 3 (each within the scatter of the next).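

In this assay, phenyl in place of 2,3-difluorophenyl gives a 1.4-fold higher number from compound 2 to compound 3 (0.14 log units; within the scatter), so the two fluorines make no readable difference at this saturated chain carbon. Phenyl in place of tert-butyl gives a 1.7-fold higher number from compound 1 to compound 3 (0.24 log units; within the scatter), so all three groups now shown at this place read alike, whether aromatic or not. Nothing available explains this flat result. Still open, as far as these compounds go, is whether an amine or a hydroxyl group on the phenyl ring, or a longer chain in place of benzyl, would stay within the same range.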